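The compounds below may be only part of what the source reports. "The series", "measured", "known", "first", "only" and "open" are said of these compounds alone.

Measured so far in a functional assay on PC-3 cells (Homo sapiens), read by fluorescence and BrdU incorporation, with a stated time of 48 h, tested at 25 uM; a lower number here means a stronger effect, a higher number a weaker effect of the compound at the concentration tested:

compound 1 `COc1cc(O)c(C(=O)/C=C/c2ccc(F)cc2)c(OC)c1`: 34%
compound 2 `COc1cc(OC)c(C(=O)/C=C/c2ccc(Cl)cc2)c(OC)c1`: 0.2%
compound 3 `COc1cccc(/C=C/C(=O)c2c(O)cc(OC)cc2OC)c1`: 9.4%

Compound 2 gives the lowest of the three numbers. Its nearest neighbour is compound 3, whose number is higher by an amount within the scatter, so no order between compound 2 and compound 3 can be read from these two values. Compound 1 stands furthest away, its number higher by an amount beyond the scatter, so compound 1 shows a weaker effect than compound 2 at the concentration tested.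

Compound 4 `COc1cc(OC)c(C(=O)/C=C/c2ccccc2)c(OC)c1` has not been measured. It differs from compound 2 in one place: hydrogen in place of chloro on an aromatic carbon. Among the compounds with values here, no pair of measured compounds shares this change, so no measured step can be carried over.

Compound 2 gives the lowest number of the three with 0.2%, so a step away from it has more room upward than downward. The expected step from a number 9.8 percentage points higher from compound 2 to compound 4 (within the scatter) is a modest rise, not certainly beyond the scatter. Compound 4 is estimated at 10%, within 0% to 35%.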

Compound 4, a percentage reported as activity, at one concentration (the size of the read-out at that concentration, not a potency): 1.7%
The estimate for compound 4 lay 8.3 percentage points above the measured number; the range from low to high includes it.
By their numbers in this assay, from the lowest: compounds 2, 4 and 3 (each within the scatter of the next); then compound 1.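

Within the data shown here, this is the first step that isolates one place. In this assay, the change from 4-chlorophenyl to phenyl gives a number 1.5 percentage points higher from compound 2 to compound 4 (within the scatter), so the read-out does not separate hydrogen from chloro on this aromatic carbon, para to a large group. Chloro at this position is therefore not required for a number in this range at the concentration tested, although a single pair cannot show how far this holds on other versions of the core. The data offer no measured basis for explaining this result.

Still open, as far as these compounds go, is whether a larger or charged group at this position, such as an amine or a carboxylic acid, would leave the number in this range. A single concentration also leaves any difference in potency between compound 2 and compound 4 unresolved.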